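Trifluoromethyl for Trifluoromethoxy: Expected Half-Life in Dog

The compounds below may be only part of what the source reports. "The series", "measured", "known", "first", "only" and "open" are said of these compounds alone.

Measured compounds:
compound 1, `O=C(O)CCNC(=O)c1ccc(CN(c2ccc(Cl)cc2)c2nc(-c3ccc(OC(F)(F)F)cc3)cs2)cc1`, 1.1 h
compound 2, `O=C(O)CCNC(=O)c1ccc(CN(c2ccc3c(c2)CCCC3)c2nc(-c3ccc(Cl)c(Cl)c3)cs2)cc1`, 2.07 h

Of the compounds shown here, two have been measured in an in vivo ADME assay on the whole organism (strain beagle) for metabolic stability, with Canis familiaris (Canis lupus familiaris) as the target, at a dose of 0.25 mg/kg by the intravenous route; on this read-out higher numbers stand for a longer-lived compound and lower numbers for a shorter-lived compound. Compound 1 gives 1.1 h, and compound 2 gives 2.07 h. These two numbers lie within the scatter of each other, so neither compound can be called the longer-lived one; they differ in several places at once, and nothing more than their two values can be read from the pair.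

Compound 3, `O=C(O)CCNC(=O)c1ccc(CN(c2ccc(Cl)cc2)c2nc(-c3ccc(C(F)(F)F)cc3)cs2)cc1`, differs from compound 1 in one place only: trifluoromethyl in place of trifluoromethoxy on an aromatic carbon. Going by the values given here, no measured pair in this set shows what such a change does in this assay, so there is no step to lean on. The expectation is therefore that compound 3 stays close to compound 1, with no step beyond the scatter in either direction. The step from compound 1 to compound 3 is expected to be a 1.1-fold higher number from compound 1 to compound 3 (0.04 log units; within the scatter). For compound 3 the estimated half-life in this assay is 1.2 h, with a range from 0.6 h to 2.5 h.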

Compound 3, half-life: 1.33 h
Compound 3: middle estimate off by 1.1-fold (0.04 log units), on the low side; the measured number falls inside the stated range.
By their numbers in this assay, from the lowest: compounds 1, 3 and 2 (each within the scatter of the next).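

Going by these compounds alone, this pair gives the first reading of a single change in this assay: putting trifluoromethyl in place of trifluoromethoxy on the aromatic carbon gives a 1.2-fold higher number from compound 1 to compound 3 (0.08 log units; within the scatter) and nothing else in the molecule differs. At this place on the six-membered aromatic ring, para to a large group, the two fluorinated groups therefore cannot be told apart by half-life, even though the oxygen atom is gone. No measured evidence bears on this result, so it stays an observation without an explanation.

Still open, from the compounds shown here alone, is whether a group of another kind at this place, such as an amine, a nitrile or a carboxylic acid, would shift the half-life beyond the scatter. Going by these compounds, the same swap on a compound with different groups elsewhere, such as compound 2, also remains untested here.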